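This account rests on a few compounds, and the source may have more. Where it says the series, first, only, none or still open, it means among the compounds named here.

Measured compounds:
compound 1 `Brc1cn2ccnc2c(-c2ccc3ncn(C4CCCCC4)c3c2)n1`: 47.6%
compound 2 `c1ccc2c(-c3cn4ccnc4c(-c4ccc5ncn(C6CCCCC6)c5c4)n3)cccc2c1`: 13%
compound 3 `CC(=O)c1ccc(-c2cn3ccnc3c(-c3ccc4ncn(C5CCCCC5)c4c3)n2)cc1`: 12%

In a functional assay on MCF7 cells (Homo sapiens) for inhibition, read by sulforhodamine B assay, with a stated time of 48 h, tested at 10 uM (a lower number here means less inhibition, a higher number more inhibition at the concentration tested (going by the name of the read-out)), compound 1 gives 47.6%, the highest of the three numbers. Replacing its bromo by naphthalen-1-yl or by 4-acetylphenyl lowered the number sharply in both measured steps: a number 34.6 percentage points lower from compound 1 to compound 2 (beyond the scatter) and a number 35.6 percentage points lower from compound 1 to compound 3 (beyond the scatter). Between compound 2 and compound 3 the step was only a number 1 percentage points lower from compound 2 to compound 3 (within the scatter), so the two replacements gave much the same result.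

Compound 4 `COc1ccccc1-c1cn2ccnc2c(-c2ccc3ncn(C4CCCCC4)c3c2)n1` makes a change of the same kind: 2-methoxyphenyl in place of bromo on an aromatic carbon. Both measured steps that bear on it were large drops, so a large drop is expected here as well, giving an estimated a number 32.6 percentage points lower from compound 1 to compound 4 (beyond the scatter). Compound 4 is therefore estimated at 15%, with a range from 0% to 35%.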

Compound 4, a percentage reported as inhibition, at one concentration (the size of the read-out at that concentration, not a potency): 8.4%
Compound 4: middle estimate off by 6.6 percentage points, on the high side; measured number inside the range.
By their numbers in this assay, from the lowest: compounds 4, 3 and 2 (each within the scatter of the next); then compound 1.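

In this assay, 2-methoxyphenyl in place of bromo brings another large drop, a number 39.2 percentage points lower from compound 1 to compound 4 (beyond the scatter), so a third aromatic group at this position falls far short of the bromo compound. The three aromatic replacements stay level, with a number 3.6 percentage points lower from compound 3 to compound 4 (within the scatter) and a number 4.6 percentage points lower from compound 2 to compound 4 (within the scatter), so naphthalen-1-yl, 4-acetylphenyl and 2-methoxyphenyl cannot be told apart here.

Nothing available explains why the bromo compound stands apart. On these data alone, it remains open whether chloro, an amine or a short alkyl chain at this position would keep the number of compound 1.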